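The source may report more compounds than this note shows. Statements on the series, on what has been measured and on what is new or still open speak of the compounds shown alone.

Working notes on the series.

Compound 1 `O=C(NCN1CCC(c2cccc[n+]2[O-])CC1)c1ccccc1` is, in a functional assay on HEK293 cells for agonist activity at D(4) dopamine receptor (Homo sapiens), read by FLIPR (on this read-out lower numbers stand for an effect already at smaller amounts and higher numbers for an effect only at larger amounts of compound), the weaker of the two measured compounds: compound 1 gives 532 nM, the highest of the two numbers. Compound 2 `Cc1cc(NC(=O)CN2CCC(c3cccc[n+]3[O-])CC2)ccc1F` differs from compound 1 in several places. In this assay, among the measured compounds shown here, compound 2 gives 18 nM, so the two measured values lie well apart, and no single-point step between them can be stated.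

Compound 3 `O=C(NCN1CCC(c2cccc[n+]2[O-])CC1)c1ccc(F)c(Cl)c1` has not been measured. Its difference from compound 1 is 3-chloro-4-fluorophenyl in place of phenyl on a carbonyl carbon, with the amide and the rest of the shared core unchanged.

For compound 3 in this assay a step toward a lower number is expected, of moderate size, with a fair chance that it stays within the scatter of compound 1; the expected step is a 2.1-fold lower number from compound 1 to compound 3 (0.33 log units; beyond the scatter). The estimate for compound 3 is 250 nM, with a range from 70 nM to 900 nM.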

Compound 3, half-maximal effective concentration: 63 nM
For compound 3 the middle estimate is 4.0-fold (0.60 log units) above the measured one; measured number outside the range, below it.
By their numbers in this assay, from the lowest: compound 2; then compound 3; then compound 1.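

Among the compounds shown here, this is the first single-place step. On a carbonyl carbon whose other neighbour is the amide-type nitrogen, 3-chloro-4-fluorophenyl in place of phenyl gives an 8.4-fold lower number from compound 1 to compound 3 (0.93 log units; beyond the scatter) in this assay, so this position responds to halogens on the ring with the rest of the shared core unchanged. Neither group carries a hydrogen-bond donor, a hydrogen-bond acceptor or a net charge, and no measurement at hand speaks to what lies behind the step.

Whether chlorine or fluorine accounts for most of the step stays open, as 3-chlorophenyl and 4-fluorophenyl on this carbonyl carbon are not among the compounds shown. Also open, as far as these compounds go, is how a ring bearing a methoxy group or a carboxylic acid, or a pyridine in place of the phenyl, would read in this assay.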